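The source may hold more compounds than are shown below. What is called first, only, known or untested is meant among the compounds shown, and "the series" means these compounds.

In a functional assay on ileum for inhibition of histamine H1 receptor (Cavia porcellus) (on this read-out higher numbers stand for weaker inhibition and lower numbers for stronger inhibition), compound 3 `CN1CCN(c2nc3ccccc3n2CCOCCO)CC1` gives 42 nM, which stands second highest of the three numbers: compound 1 `CCCOCCn1c(N2CCN(C)CC2)nc2ccccc21` gives 20 nM and compound 2 `CCCCCCCn1c(N2CCN(C)CC2)nc2ccccc21` gives 150 nM. Compound 4 `CCCSCn1c(N2CCN(C)CC2)nc2ccccc21` differs from compound 3 by propylsulfanyl in place of (2-hydroxyethoxy)methyl on a saturated chain carbon bound to an aromatic nitrogen. Within the data shown here, two measured steps bear on this. The step of a 2.1-fold higher number from compound 1 to compound 3 (0.32 log units; beyond the scatter) shows that a hydroxy in place of a methyl raises the number modestly, so its removal may lower it. The step of a 7.5-fold higher number from compound 1 to compound 2 (0.88 log units; beyond the scatter) shows that losing the chain oxygen raises the number. Compound 4 loses both the hydroxy and the oxygen, gaining a sulfur, so the two effects are expected to largely offset, giving an expected step of a 1.1-fold lower number from compound 3 to compound 4 (0.02 log units; within the scatter) in this assay. Compound 4 is therefore estimated at 40 nM, in the range 12 nM to 150 nM.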

Compound 4, half-maximal inhibitory concentration: 68 nM
For compound 4 the middle estimate is 1.7-fold (0.23 log units) below the measured one; low and high end bracket the measured number.
By their numbers in this assay, from the lowest: compound 1; then compounds 3 and 4 (each within the scatter of the next); then compound 2.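

In this assay, propylsulfanyl in place of (2-hydroxyethoxy)methyl gives a 1.6-fold higher number from compound 3 to compound 4 (0.21 log units; within the scatter), so on this saturated chain carbon the change removes the hydrogen-bond donor without a step beyond the scatter. Propylsulfanyl still falls short of propoxymethyl, with a 3.4-fold higher number from compound 1 to compound 4 (0.53 log units; beyond the scatter), yet it does better than hexyl, with a 2.2-fold lower number from compound 2 to compound 4 (0.34 log units; beyond the scatter). Nothing available here explains these steps. From the compounds shown here alone, whether an amine, a carboxylic acid or a longer sulfur-bearing chain on this saturated chain carbon would match compound 1 remains open.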